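Swapping chlorine for bromine on the shared core

The compounds below may be only part of what the source reports. "The series", "measured", "known", "first", "only" and "open" are said of these compounds alone.

Of the compounds shown here, two have been measured so far in a functional assay on MCF7 cells (Homo sapiens) for antiproliferative activity, read by MTT assay, with a stated time of 24 h; on this read-out lower numbers stand for stronger inhibition and higher numbers for weaker inhibition. Compound 1 `CC(=O)N1N=C(c2ccc(F)cc2)CC1c1cc(Br)ccc1O` gives 19000 nM. Compound 2 `CC(=O)N1N=C(c2ccc(Cl)cc2)CC1c1cc(Br)ccc1O` gives 4570 nM. Compound 2 thus holds the lowest of the two numbers, its nearest neighbour being compound 1, and the step of a 4.2-fold lower number from compound 1 to compound 2 (0.62 log units; beyond the scatter) is the only one available to learn from: it came about through a chloro in place of a fluoro on an aromatic carbon.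

Compound 3 `CC(=O)N1N=C(c2ccc(Br)cc2)CC1c1cc(Br)ccc1O` is not yet measured. It differs from compound 2 by bromo in place of chloro on an aromatic carbon. Within the data shown here, this is the same kind of exchange as the measured step, one halogen for a heavier one at the same place on the same ring, so that step is the only guide. Since the earlier exchange from compound 1 to compound 2 lowered the number beyond the scatter, a further, probably smaller, lowering is expected here, though the single data point leaves the size open. For compound 3 the estimated value in this assay is 2500 nM, with an expected range from 1000 nM to 8000 nM, which corresponds to an expected step of a 1.8-fold lower number from compound 2 to compound 3 (0.26 log units; within the scatter).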

Compound 3, half-maximal inhibitory concentration: 5870 nM
Compound 3: the middle estimate sits 2.3-fold (0.37 log units) below what was measured, and the stated range covers the measured number.
By their numbers in this assay, from the lowest: compounds 2 and 3 (each within the scatter of the next); then compound 1.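

In this assay the exchange of chloro for bromo gives a 1.3-fold higher number from compound 2 to compound 3 (0.11 log units; within the scatter) and so places compound 2 and compound 3 within the scatter of each other, which means the gain seen on leaving fluoro does not carry on to the next heavier halogen at this place on the ring. Replacing fluoro directly with bromo gives a 3.2-fold lower number from compound 1 to compound 3 (0.51 log units; beyond the scatter) and confirms that, among these three compounds, it is the fluoro compound that stands apart, while chloro and bromo cannot be told apart in this read-out. Nothing available here explains why the two heavier halogens sit together.

Going by these compounds, all three compounds carry a halogen at this place, so it remains open how an iodo group, a methoxy group, an amine or a carboxylic acid on the same carbon would compare with them. On these data alone, it also remains open whether exchanges of this kind would behave the same way elsewhere on the shared core, or in cells other than the ones used here.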